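This account rests on a few compounds, and the source may have more. Where it says the series, first, only, none or still open, it means among the compounds named here.

Compound 1 `COc1cc(C2=NN(C(C)=O)C(c3ccc(F)cc3)O2)cc(OC)c1OC` is the weaker of the two compounds measured in a functional assay on PC-3 cells (Homo sapiens) for antiproliferative activity, read by MTT assay, tested at 5 uM; on this read-out higher numbers stand for a stronger effect at the one concentration tested and lower numbers for a weaker effect: compound 1 gives 0.1%, while compound 2 `COc1cc(/C=N/NC(=O)c2cc(OC)c(OC)c(OC)c2)cc(OC)c1OC` gives 48.3%, a gap far wider than the usual scatter. Compound 3 `COc1cc(C2=NN(C(C)=O)C(c3cccc(C(F)(F)F)c3)O2)cc(OC)c1OC` keeps the core of compound 1 and changes one group: 3-(trifluoromethyl)phenyl in place of 4-fluorophenyl on a saturated ring carbon. Among the measured compounds shown here, no measured pair shows what this change does, so the step from compound 1 to compound 3 is expected to be small, if anything upward, within or only slightly beyond the scatter, a number 9.9 percentage points higher from compound 1 to compound 3 (within the scatter). Compound 3 is therefore estimated at 10% in this assay, between 0% and 35%.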

Compound 3, a percentage reported as inhibition, at one concentration (the size of the read-out at that concentration, not a potency): 43.6%
Estimate against measurement, compound 3: 33.6 percentage points below; measured number above the stated range.
By their numbers in this assay, from the lowest: compound 1; then compounds 3 and 2 (each within the scatter of the next).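

In this assay, replacing 4-fluorophenyl with 3-(trifluoromethyl)phenyl on the saturated ring carbon gives a number 43.5 percentage points higher from compound 1 to compound 3 (beyond the scatter), so the group at this place matters for the read-out. The shared core stays the same, and this one exchange alone separates a near-zero effect from a clear one at the single concentration tested. Nothing shown here explains the gain. From the compounds shown here alone, the substituent and its place on the phenyl ring change together, so it stays open which one counts; 4-(trifluoromethyl)phenyl or 3-fluorophenyl would separate them. Going by these compounds, how a phenyl bearing an amine or a carboxylic acid behaves here also remains open.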